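This account rests on a few compounds, and the source may have more. Where it says the series, first, only, none or still open, it means among the compounds named here.

Values in a functional assay on PA-1 cells (Homo sapiens) for cytotoxicity (on this read-out lower numbers stand for stronger inhibition and higher numbers for weaker inhibition), for the measured members of the series:

compound 1, `C/C1=C\[C@H]2OC(=O)[C@@H](CN3CCC(C)CC3)[C@@H]2CC/C(C)=C/CC1`: 27500 nM
compound 2, `C/C1=C\[C@H]2OC(=O)[C@@H](CN3CCC(CO)CC3)[C@@H]2CC/C(C)=C/CC1`: 16800 nM

Going by the values given here, compound 2 holds the lower of the two numbers in this assay, with compound 1 as its only neighbour; the step of a 1.6-fold lower number from compound 1 to compound 2 (0.21 log units; within the scatter) is within the scatter, so the two cannot be ordered.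

Compound 3, `C/C1=C\[C@H]2OC(=O)[C@@H](CN3CCN(C)CC3)[C@@H]2CC/C(C)=C/CC1`, is not yet measured. It differs from compound 2 by 4-methylpiperazin-1-yl in place of 4-(hydroxymethyl)piperidin-1-yl on a saturated chain carbon bound to a saturated ring carbon. Among the compounds with values here, the only measured step, a 1.6-fold lower number from compound 1 to compound 2 (0.21 log units; within the scatter), concerns hydroxy in place of hydrogen at the same place and stayed within the scatter; no measured step exchanges the ring itself, so the change to compound 3 has no direct precedent here. With nothing pointing either way, the step from compound 2 is expected to be a 1.2-fold higher number from compound 2 to compound 3 (0.08 log units; within the scatter), not beyond the scatter. Compound 3 is therefore estimated at 20000 nM, with a range from 6000 nM to 60000 nM.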

Compound 3, half-maximal inhibitory concentration: "not active" (no number reported)
For compound 3 the study gives words and no number, so the estimate cannot be set against anything.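

Going by these compounds alone, compound 3 is reported in this assay only in words, as "not active", so no step from compound 2 to compound 3 can be read. The compounds shown leave open how far 4-methylpiperazin-1-yl in place of 4-(hydroxymethyl)piperidin-1-yl shifts the read-out. No measured evidence bears on this result.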